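The compounds below may be only part of what the source reports. "The series", "measured", "known", "first", "only" and "open" are said of these compounds alone.

Of the compounds shown here, two share a core and have been tested so far. Compound 1 `N#Cc1ccc(Nc2nc(Oc3ccnc4ccccc34)nc(N3CCN(c4ccccc4Cl)CC3)n2)cc1C(F)(F)F` gives 92600 nM in a functional assay on DU-145 cells (Homo sapiens) for cytotoxicity, read by sulforhodamine B assay, with a stated time of 48 h; a higher number here means a weaker inhibitor of growth, a lower number a stronger inhibitor of growth. Among the measured compounds shown here, compound 2 `CN1CCN(c2nc(Nc3ccc(C#N)c(C(F)(F)F)c3)nc(Oc3ccnc4ccccc34)n2)CC1` gives 51200 nM in this assay, the lower of the two numbers, yet the only step known, a 1.8-fold lower number from compound 1 to compound 2 (0.26 log units; within the scatter), stays within the scatter, so the two values cannot be ranked. Compound 3 `COc1ccc(N2CCN(c3nc(Nc4ccc(C#N)c(C(F)(F)F)c4)nc(Oc4ccnc5ccccc45)n3)CC2)cc1` has not yet been measured. It differs from compound 2 by 4-methoxyphenyl in place of methyl on an amine nitrogen in a ring. For the measured compounds named here, the one measured step bears on this change only in reverse: replacing an aryl group on that ring nitrogen by methyl moved the number by no more than the scatter, so putting a different aryl group back in place of methyl is expected to shift the number little, if at all. Compound 3 is therefore expected to give about 70000 nM in this assay, somewhere between 30000 nM and 160000 nM, which means an expected step of a 1.4-fold higher number from compound 2 to compound 3 (0.14 log units; within the scatter).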

Compound 3, concentration for 50% growth inhibition: > 100000 nM
Compound 3: only a limit was reported; the forecaster's own chance of this, stated with the estimate: 10%; middle value at least 1.4-fold (0.15 log units) from the limit.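

Compound 3 gives no number in this assay, only a limit of the assay: the limit of > 100000 nM in this assay, at which 1 of the 3 values shown sits.

Putting 4-methoxyphenyl on this ring nitrogen gives an at least 1.9-fold higher number from compound 2 to compound 3 (0.29 log units; that floor lies within the scatter) when it replaces methyl, and an at least 1.0-fold higher number from compound 1 to compound 3 (0.03 log units; that floor lies within the scatter) when it replaces 2-chlorophenyl. This adds a second aryl group to the comparison at this position, and it brings no lower number than methyl or 2-chlorophenyl, although neither floor is enough to rank compound 3 against the other two.

As far as these compounds go, the true value of compound 3 remains unknown, so it is open how far this change really moves the number. From the compounds shown here alone, it is also open whether a different kind of group on this ring nitrogen, such as a longer chain ending in an amine or a carboxylic acid, would give a clearly lower number.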